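Swapping an Acetyl for a Bromophenylsulfonyl at the Phenol

The compounds below may be only part of what the source reports. "The series", "measured", "known", "first", "only" and "open" are said of these compounds alone.

compound 1 `CC(=O)Oc1ccc(-c2cncn2C2CCN(C(=O)c3ccc(Cl)c(C(F)(F)F)c3)CC2)cc1` — in an assay on HEK293 cells for antagonist activity at P2X purinoceptor 7 (Homo sapiens), read by fluorescence, with a stated time of 2 h (on this read-out higher numbers stand for weaker inhibition and lower numbers for stronger inhibition), compound 1 gives only a limit, > 10000 nM
compound 2 `O=C(c1ccc(Cl)c(C(F)(F)F)c1)N1CCC(n2cncc2-c2ccc(OS(=O)(=O)c3cccs3)cc2)CC1` — compound 2 gives 238 nM
compound 3 `O=C(c1ccc(Cl)c(C(F)(F)F)c1)N1CCC(n2cncc2-c2ccc(OS(=O)(=O)c3cccc4ccccc34)cc2)CC1` — compound 3 gives 3520 nM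

Compound 1 sits at the limit of > 10000 nM in this assay, at which 1 of the 3 values shown sits, so no number is known for it, only that it lies at that limit. Compound 4 `O=C(c1ccc(Cl)c(C(F)(F)F)c1)N1CCC(n2cncc2-c2ccc(OS(=O)(=O)c3cccc(Br)c3)cc2)CC1` differs from compound 1 in one place: (3-bromophenyl)sulfonyl in place of acetyl on an oxygen on an aromatic ring. Among the compounds with values here, two measured steps bear on this change. The step of an at least 42-fold lower number from compound 1 to compound 2 (1.62 log units; beyond the scatter) shows that putting an aryl sulfonyl in place of the acetyl lowers the number strongly. The step of a 15-fold higher number from compound 2 to compound 3 (1.17 log units; beyond the scatter) shows that the ring on the sulfonyl sulfur matters, since the naphthalen-1-yl version gave a far higher number than the thiophen-2-yl one. A single six-membered ring is closer in kind to compound 2 than to compound 3, so compound 4 is expected to show a large drop, an at least 16-fold lower number from compound 1 to compound 4 (1.22 log units; beyond the scatter). Compound 4 is therefore estimated at 600 nM, within a range of 150 nM to 3000 nM.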

Compound 4, half-maximal inhibitory concentration: 896 nM
The estimate for compound 4 lay 1.5-fold (0.17 log units) below the measured number; the range from low to high includes it.
By their numbers in this assay, from the lowest: compound 2; then compound 4; then compound 3. At a limit, above all of these: compound 1.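

In this assay, a second aryl sulfonyl also gives a large gain over the acetyl, with an at least 11-fold lower number from compound 1 to compound 4 (1.04 log units; beyond the scatter), so the gain at this oxygen is not tied to the thiophen-2-yl ring. Compound 1 has only a limit, so that step has no exact size: the limit of > 10000 nM in this assay, at which 1 of the 4 values shown sits. The ring on the sulfonyl sulfur still tunes the number, with a 3.9-fold lower number from compound 3 to compound 4 (0.59 log units; beyond the scatter) and a 3.8-fold higher number from compound 2 to compound 4 (0.58 log units; beyond the scatter). What the bromine itself contributes stays open, since a plain phenyl ring is not among these compounds. Also open, as far as these compounds go, is how an amine or a carboxylic acid on that ring, or a simple methyl on the sulfonyl sulfur, would behave.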